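Amino in place of nitro: cytotoxicity working notes

This account rests on a few compounds, and the source may have more. Where it says the series, first, only, none or still open, it means among the compounds named here.

Compound 1 `Cc1cc(Br)cc(C)c1Oc1ccc([N+](=O)[O-])c(Nc2ccc(C#N)cc2)c1`: in an ADME assay on H9 cells (Homo sapiens) for cytotoxicity, read by XTT assay, with a stated time of 6 days (on this read-out higher numbers stand for lower toxicity in this test and lower numbers for higher toxicity in this test), compound 1 gives > 57000 nM, which is a limit of the assay.
Compound 2 `Cc1cc(Br)cc(C)c1Oc1ccc(N)c(Nc2ccc(C#N)cc2)c1`: in this assay compound 2 gives 44600 nM.
Compound 3 `Cc1cc(C#N)cc(C)c1Oc1cc(Nc2ccc(C#N)cc2)c([N+](=O)[O-])cc1[N+](=O)[O-]`: in this assay compound 3 gives > 58200 nM, which is a limit of the assay.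

The change from compound 1 to compound 2 is amino in place of nitro on an aromatic carbon. The step is an at least 1.2-fold lower number from compound 1 to compound 2 (0.10 log units; that floor lies within the scatter); its floor rests on (the limit of > 57000 nM in this assay, at which 1 of the 3 values shown sits), so only a floor for the step is known. The value of compound 3 sits at the limit of > 58200 nM in this assay, at which 1 of the 3 values shown sits, again a limit and not a number. The difference between the core of compound 1 and the core of compound 3 is not broken down here.

Compound 4 `Cc1cc(C#N)cc(C)c1Oc1cc(Nc2ccc(C#N)cc2)c(N)cc1[N+](=O)[O-]` is not yet measured in this assay. Its change from compound 3 is amino in place of nitro on an aromatic carbon. The place is not the same word for word as in the earlier change: here the aromatic carbon is also meta to a nitro group. It is therefore the same kind of change, not the same change.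

For compound 4 the step is expected to be about an at least 1.4-fold lower number from compound 3 to compound 4 (0.16 log units; that floor lies within the scatter), alongside an at least 1.2-fold lower number from compound 1 to compound 2 (0.10 log units; that floor lies within the scatter), resting on compound 2 giving 44600 nM after the same kind of change. Compound 4 is estimated at 40000 nM, within 15000 nM to 60000 nM, with a real chance that the assay again reports only a limit.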

Compound 4, half-maximal cytotoxic concentration: 62700 nM
Estimate against measurement, compound 4: 1.6-fold (0.20 log units) below; measured number above the stated range.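

The step from compound 3 to compound 4 cannot be read, because the value of compound 3 is a limit of the assay and not a number: the limit of > 58200 nM in this assay, at which 1 of the 4 values shown sits.
The compounds shown leave open how large the change of amino in place of nitro is in this assay on the core of compound 3, and whether it matches the change on the core of compound 1.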